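A Fluoro Swap on the Lower-Valued Compound

The source may hold more compounds than are shown below. What is called first, only, known or untested is meant among the compounds shown, and "the series" means these compounds.

Within the data shown here, in a functional assay on A549 cells (Homo sapiens) for cytotoxicity, read by MTT assay, with a stated time of 72 h (a higher number here means a weaker inhibitor, a lower number a stronger inhibitor), compound 2 `O=S(=O)(c1ccccc1)c1nc2ccccc2nc1N1CCC(O)CC1` gives 2060 nM and stands lowest of the two numbers so far. Compound 1 `O=S(=O)(c1ccc(F)cc1)c1nc2ccccc2nc1N1CCc2ccccc2C1` gives 22900 nM in the same measurement. The gap between compound 2 and compound 1 lies beyond the scatter. Compound 3 `O=S(=O)(c1ccc(F)cc1)c1nc2ccccc2nc1N1CCC(O)CC1` departs from compound 2 by fluoro in place of hydrogen on an aromatic carbon and carries fluoro in place of hydrogen on an aromatic carbon, turning phenyl to 4-fluorophenyl. Among the measured compounds shown here, no measured pair shows this change alone. In this assay the estimated 1.3-fold higher number from compound 2 to compound 3 (0.10 log units; within the scatter) is expected to stay within the scatter, leaning slightly upward. Compound 3 is estimated at 2600 nM with a range from 1100 nM to 6500 nM in this measurement.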

Compound 3, half-maximal inhibitory concentration: 20200 nM
Compound 3: the middle estimate sits 7.8-fold (0.89 log units) below what was measured, and the stated range ends below it.
By their numbers in this assay, from the lowest: compound 2; then compounds 3 and 1 (each within the scatter of the next).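

In this assay, phenyl to 4-fluorophenyl proves to be no neutral swap at this position: the single fluoro gives a 9.8-fold higher number from compound 2 to compound 3 (0.99 log units; beyond the scatter) and so removes the advantage that compound 2 held. With 4-fluorophenyl in place, the change to 4-hydroxypiperidin-1-yl gives a 1.1-fold lower number from compound 1 to compound 3 (0.05 log units; within the scatter) and separates nothing. Nothing available explains the effect of the fluoro. On these data alone, whether a chlorine atom or a methoxy group at the same place would act as fluoro does remains open. So does how 1,2,3,4-tetrahydroisoquinolin-2-yl behaves alongside plain phenyl.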